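A few compounds are considered here, and "the series" means these few. Any claim that something is new, unique, unknown or untested is made for them only; others in the source may bear on it.

Of the compounds shown here, three have so far been measured in a functional assay on MIA PaCa-2 cells (Homo sapiens) for cytotoxicity, read by luminescence, with a stated time of 72 h, in the presence of a further agent that is not named here; a lower number here means a stronger inhibitor, a higher number a weaker inhibitor. Compound 1 `CNC(=S)N/N=C/c1nccc2cc(F)ccc12` gives 233 nM in this assay. Compound 2 `NC(=S)N/N=C/c1nccc2cc(F)ccc12` differs from compound 1 by hydrogen in place of methyl on an amide-type nitrogen. In this assay compound 2 gives 2040 nM, so that the step is an 8.8-fold higher number from compound 1 to compound 2 (0.94 log units; beyond the scatter). Compound 3 `CNC(=S)N/N=C/c1ncc(F)c2ccccc12` is built from the same atoms as compound 1, joined differently; the difference between the two cores is not broken down here. In this assay compound 3 gives 114 nM, the lowest of the three numbers, with compound 1 nearest to it and compound 2 furthest away.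

Compound 4 `NC(=S)N/N=C/c1ncc(F)c2ccccc12` has not yet been measured. It differs from compound 3 by hydrogen in place of methyl on an amide-type nitrogen, which is the same change as that from compound 1 to compound 2, at a place described in the same words. That change has been seen only once among these compounds, and it made the number larger by a modest amount. Within the data shown here, whether the core of compound 3 answers to the same change in the same way is not known from the data at hand, so the single earlier step is the only guide. For compound 4 the expected step is an 8.8-fold higher number from compound 3 to compound 4 (0.94 log units; beyond the scatter). That expectation rests on an 8.8-fold higher number from compound 1 to compound 2 (0.94 log units; beyond the scatter). In this assay compound 4 is therefore expected to give about 1000 nM, with a likely range from 400 nM to 2500 nM.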

Compound 4, half-maximal inhibitory concentration: 2060 nM
For compound 4 the middle estimate is 2.1-fold (0.31 log units) below the measured one; low and high end bracket the measured number.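

In this assay, hydrogen in place of methyl on the amide-type nitrogen again gives a weaker compound, with an 18-fold higher number from compound 3 to compound 4 (1.26 log units; beyond the scatter). The step looks larger on this core than on the core of compound 1, but that gap is too small to count as a real difference, so the two cores answer to the change alike as far as these numbers can tell: the same change on two cores in this assay, an 8.8-fold higher number (0.94 log units; beyond the scatter) from compound 1 to compound 2 and an 18-fold higher number (1.26 log units; beyond the scatter) from compound 3 to compound 4, 2.1-fold (0.31 log units) apart, within the scatter of two such steps. This supports carrying the change between these two cores in this assay, but two pairs cannot show that it would hold on any other core, and the numbers alone do not explain why the methyl group matters.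

The compounds shown carry only methyl or hydrogen on this nitrogen, so it remains open whether an ethyl group, a longer chain or a cyclopropyl ring at that place would continue the trend or break it. As far as these compounds go, it also remains open how the same change would behave on a core carrying chlorine in place of fluorine, or on one with no halogen at all.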